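Turning an imine around on a bromoquinoxaline core

This account rests on a few compounds, and the source may have more. Where it says the series, first, only, none or still open, it means among the compounds named here.

Measured so far:
- compound 1 `Cc1nc2cc(Br)ccc2n(CC(=O)NN)c1=O`: 0.00001 ug/mL
- compound 2 `Cc1nc2cc(Br)ccc2nc1Sc1ccccc1`: 0.0122 ug/mL
- compound 3 `Cc1nc2cc(Br)ccc2nc1Oc1ccc(/N=C\c2ccc(Cl)cc2)cc1`: 0.00008 ug/mL

Of the compounds shown here, three share the same brominated core and have been tested in a functional assay on MCF7 cells (Homo sapiens) for inhibition, read by sulforhodamine B assay, with a stated time of 72 h; a lower number here means a stronger inhibitor, a higher number a weaker inhibitor. Compound 1 gives 0.00001 ug/mL, compound 2 gives 0.0122 ug/mL, and compound 3 gives 0.00008 ug/mL. Among these three numbers compound 3 stands second highest. Its nearest neighbour is compound 1, whose number is lower by a gap beyond the usual scatter; its furthest is compound 2, whose number is higher by a gap well beyond the scatter. No two of these compounds differ in just one place, so no single step between measured compounds can be read off.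

Compound 4 `Cc1nc2cc(Br)ccc2nc1Oc1ccc(/C=N\c2ccc(Cl)cc2)cc1` has not yet been measured. It differs from compound 3 by a group of 9 heavy atoms (7 carbon, 1 nitrogen, 1 chlorine; one six-membered aromatic ring of carbon only) in place of a group of 9 heavy atoms (7 carbon, 1 nitrogen, 1 chlorine; one six-membered aromatic ring of carbon only), on an aromatic carbon. Compound 3 and compound 4 have the same atoms, joined differently, with the double bond outside the aromatic rings pointing the other way along the same link.

A rearrangement of this kind, with no atom gained or lost, is expected to shift the number only a little in this assay, likely within the scatter. Compound 4 is estimated at 0.0001 ug/mL, with a range from 0.00002 ug/mL to 0.0006 ug/mL. The step from compound 3 to compound 4 is therefore expected to be a 1.3-fold higher number from compound 3 to compound 4 (0.10 log units; within the scatter), in no firm direction.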

Compound 4, half-maximal inhibitory concentration: 0.0126 ug/mL
Estimate against measurement, compound 4: 130-fold (2.10 log units) below; measured number outside the range, above it.
By their numbers in this assay, from the lowest: compound 1; then compound 3; then compounds 2 and 4 (each within the scatter of the next).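

Going by these compounds alone, compound 3 and compound 4 hold the same atoms, and the only change is the direction of the imine link, the double bond outside the aromatic rings, on an aromatic carbon para to a large group. Even so, this assay shows a 160-fold higher number from compound 3 to compound 4 (2.20 log units; beyond the scatter), so compound 4 is the much weaker inhibitor of this pair. At this position, then, the same atoms, the same ring and the same hydrogen-bond counts do not settle the number, something the earlier compounds could not show, as no two of them differed in just one place, and nothing measured here explains why the direction of the link matters so much.

From the compounds shown here alone, this is a single pair, so it remains open whether the same large step would appear if a methoxy group or an amine replaced the chlorine on the ring that the link carries. Going by these compounds, it is also open whether an amide or a saturated aminomethylene link in place of the imine would give a number closer to that of compound 3 or to that of compound 4.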